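Swapping bromo for nitro on a shared amide core

The source may hold more compounds than are shown below. What is called first, only, known or untested is meant among the compounds shown, and "the series" means these compounds.

Compound 1, `COC(=O)c1cc(-c2cccc(NC(=O)c3ccc(C4OC4C(=O)c4ccc(Cl)cc4)cc3)c2)on1`: > 20 ug/mL
Compound 2, `COC(=O)c1cc(-c2cccc(NC(=O)c3ccc(/C=C/C(=O)c4cccc(Br)c4)cc3)c2)on1`: > 100 ug/mL

Of the compounds shown here, two built on the same core have been tested in an ADME assay on Vero cells (Chlorocebus sabaeus) for cytotoxicity, read by MTT assay, with a stated time of 72 h; a higher number here means that more compound is tolerated, a lower number that less compound is tolerated. For compound 1 the result > 20 ug/mL is a limit of the assay, not a number. For compound 2 the result > 100 ug/mL is likewise a limit. The two limits leave the step that the two limits leave unreadable from compound 1 to compound 2 unreadable, so it gives no measured size to lean on. Compound 2 stands at the limit described by the limit of > 100 ug/mL in this assay, at which 1 of the 2 values shown sits, compound 1 at the one described by the limit of > 20 ug/mL in this assay, at which 1 of the 2 values shown sits.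

Compound 3, `COC(=O)c1cc(-c2cccc(NC(=O)c3ccc(/C=C/C(=O)c4cccc([N+](=O)[O-])c4)cc3)c2)on1`, differs from compound 2 by nitro in place of bromo on an aromatic carbon. Within the data shown here, no measured step covers this change, so there is no measured guide to its size or direction. The expected step is a number no higher from compound 2 to compound 3 (the limit leaves the size open), none beyond the scatter. Compound 3 is estimated at 100 ug/mL, with a range from 40 ug/mL to 200 ug/mL.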

Compound 3, half-maximal cytotoxic concentration: > 40 ug/mL
Compound 3: a limit, no number; the forecaster's own chance of this, stated with the estimate: 65%; the middle value is on the limit's open side.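

In this assay, compound 2 and compound 3 both give limits rather than numbers, so no step can be read between them. The compounds shown leave open whether nitro in place of bromo changes how much compound the cells tolerate, and in which direction.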